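This account rests on a few compounds, and the source may have more. Where it says the series, first, only, none or still open, it means among the compounds named here.

Working notes on the series.

The shared core carries a methyl ester and an ether chain ending in a terminal alkyne; the chain length is the one variable. Compound 1 `C#CCOc1ccc2cc(C(=O)OC)c(=O)oc2c1` gives 1790 nM in an assay on cells for inhibition of Amine oxidase [flavin-containing] B (Homo sapiens), read by Amplex Red, with stated times of 30 min and 45 min; a lower number here means a stronger inhibitor, a higher number a weaker inhibitor. Compound 2 `C#CCCOc1ccc2cc(C(=O)OC)c(=O)oc2c1` gives 258 nM in this assay. Going by the values given here, the only step measured so far is a 6.9-fold lower number from compound 1 to compound 2 (0.84 log units; beyond the scatter), and on that basis compound 2 stands with the lowest number of the two measured compounds, compound 1 being its only neighbour.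

The next member, compound 3 `C#CCCCOc1ccc2cc(C(=O)OC)c(=O)oc2c1`, has not been measured. Its difference from compound 2 is propargyl in place of ethynyl on a saturated chain carbon, two bonds along the chain from an oxygen on an aromatic ring. Among the compounds with values here, the one measured step that bears on this change is a 6.9-fold lower number from compound 1 to compound 2 (0.84 log units; beyond the scatter), which lengthened the same chain by one carbon and was modest but beyond the scatter. Whether a second lengthening continues in the same direction is not shown by any measured pair, so the expectation leans on that single step and is tempered accordingly.

For compound 3 the estimate is 180 nM in this assay, with a range of 50 nM to 700 nM. This amounts to an expected step of a 1.4-fold lower number from compound 2 to compound 3 (0.16 log units; within the scatter), smaller than the step already seen and possibly within the scatter.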

Compound 3, half-maximal inhibitory concentration: 82.4 nM
Beside the measured number, compound 3's estimate is 2.2-fold (0.34 log units) above it; measured number inside the range.
By their numbers in this assay, from the lowest: compound 3; then compound 2; then compound 1.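

With the pent-4-yn-1-yl ether, the second lengthening of the chain in this assay goes the same way as the first, giving a 3.1-fold lower number from compound 2 to compound 3 (0.50 log units; beyond the scatter) as the new step, so the fall in the number seen earlier does not stop at but-3-yn-1-yl. Taken end to end, the change from the shortest to the longest of the three chains gives a 22-fold lower number from compound 1 to compound 3 (1.34 log units; beyond the scatter) and is graded large, while each single step is graded modest; across these three compounds the number falls with every lengthening, and none of them goes against that. Nothing at hand accounts for this trend in terms of cause.

Still open, from the compounds shown here alone, is whether a longer chain, such as hex-5-yn-1-yl, lowers the number further in this assay or marks the point where the trend turns. The compounds shown also leave untested whether the terminal alkyne matters at all, as a saturated pentyl chain or a nitrile at the chain end would show, and whether the trend holds with a carboxylic acid or an amide in place of the methyl ester.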